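A few compounds are considered here, and "the series" means these few. Any claim that something is new, unique, unknown or untested is made for them only; others in the source may bear on it.

Measured compounds:

- compound 1, `OC[C@@]1(c2ccc(F)cc2)NC[C@@H](O)[C@@H]1O`, in an assay on isolated protein for inhibition of alpha-mannosidase (Canavalia ensiformis), tested at 1000 uM (a higher number here means more inhibition at the concentration tested (going by the name of the read-out), a lower number less inhibition), gives 6.6%
- compound 2, `OC[C@]1(c2ccc(F)cc2)NC[C@H](O)[C@H]1O`, in this assay gives 6.6%

Compound 1 stands level with compound 2 at the digits shown; the two are mirror images, and the step of no change at the digits printed from compound 1 to compound 2 (within the scatter) stays within the scatter, which the fact that compounds 1 and 2 differ only in the configuration as drawn alone accounts for: inverting every stereocentre leaves the read-out where it was.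

The unmeasured compound is compound 3, `Cc1ccc([C@]2(CO)NC[C@@H](O)[C@@H]2O)cc1`. It differs from compound 1 in one place: methyl in place of fluoro on an aromatic carbon. Within the data shown here, no measured step concerns a change on the aromatic ring; the only step available, from compound 1 to compound 2, is a change of configuration and not of substituent, and it was flat. Compound 1 gives a low read-out in this assay, and nothing measured here points to the methyl moving it far in either direction. Compound 3 is therefore expected to stay near compound 1, with the step of a number 1.4 percentage points higher from compound 1 to compound 3 (within the scatter) estimated as none beyond the scatter. For compound 3 the estimate in this assay is 8%, within a range from 0% to 25%.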

Compound 3, a percentage reported as inhibition, at one concentration (the size of the read-out at that concentration, not a potency): 0%
For compound 3 the middle estimate is 8 percentage points above the measured one; the range from low to high includes it.
By their numbers in this assay, from the lowest: compounds 3, 1 and 2 (each within the scatter of the next).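

In this assay, among these compounds, the aromatic ring now has a measured step of its own, where the earlier compounds spoke only to configuration. Methyl in place of fluoro on an aromatic carbon, para to a group of 9 heavy atoms, gives a number 6.6 percentage points lower from compound 1 to compound 3 (within the scatter) and so does not separate the two groups at this position, at least on the shared core and at the one concentration tested. All three compounds now lie within the scatter of one another, and nothing at hand bears on why this exchange leaves the read-out where it does.

What the compounds shown leave open is whether any other group at this place, such as an amine, a carboxylic acid or a longer chain, would move the read-out clear of the scatter, since fluoro and methyl are the only two groups seen there. Also open, from the compounds shown here alone, is whether the exchange of fluoro for methyl would stay as flat on a compound with a much higher read-out, as all three values here are low.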